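The compounds below may be only part of what the source reports. "The series", "measured", "known", "first", "only" and "open" are said of these compounds alone.

Compound 3, `O=C(O)CCc1ccc(C#Cc2ccnc(-c3ccccc3)c2)cc1`, is measured in an in vitro functional assay on 1321-N1 cells for agonist activity at Free fatty acid receptor 1 (Homo sapiens), read by fluorescence, spectrophotometry and calcium flux (a lower number here means a smaller maximal response, a higher number a larger maximal response), where compound 3 gives 97%. On the numbers shown it stands second highest of three. Its nearest neighbour is compound 1, `Cc1ccccc1-c1cc(C#Cc2ccc(CCC(=O)O)cc2)ccn1`, which in this assay gives 92%; the furthest is compound 2, `Cc1cc(C#Cc2ccc(CCC(=O)O)cc2)nc(Cl)n1`, which in this assay gives 110%. Among the measured compounds shown here, the single step among the measured compounds, from compound 1 to compound 3, changed the response by a number 5 percentage points higher from compound 1 to compound 3 (within the scatter), a hydrogen in place of a methyl on an aromatic carbon.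

Compound 4, `O=C(O)CCc1ccc(C#Cc2ccnc(F)c2)cc1`, differs from compound 3 by fluoro in place of phenyl on an aromatic carbon. No measured step bears on this change: the one step available concerns a methyl removed at a different carbon, and for the pair compound 2 and compound 3 only the two values themselves are shown. Taken as a whole, the three numbers sit within a narrow band, so the shared core appears to keep a full maximal response across these variations. Because compound 3 gives 97% and compound 2 gives 110%, the step from compound 3 to compound 4 is expected to be a number 2 percentage points lower from compound 3 to compound 4 (within the scatter), no change beyond the scatter. Compound 4 is therefore estimated at 95%, with a range from 72% to 115%.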

Compound 4, largest response reached (reported as efficacy), in percent of the reference or control that the assay uses: 98%
Compound 4: middle estimate off by 3 percentage points, on the low side; the measured number falls inside the stated range.
By their numbers in this assay, from the lowest: compounds 1, 3 and 4 (each within the scatter of the next); then compound 2.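

At the carbon next to the ring nitrogen, fluoro, a single heavy atom with no ring, replaced phenyl, with its six heavy atoms and six-membered aromatic ring, giving a number 1 percentage points higher from compound 3 to compound 4 (within the scatter) in this assay and leaving the maximal response in place. Replacing the 2-methylphenyl group with fluoro gave a number 6 percentage points higher from compound 1 to compound 4 (within the scatter) and told the same story, whereas the earlier step had only removed a methyl and left the aromatic ring at this position intact; among compound 1, compound 3 and compound 4, then, this response does not depend on an aromatic ring at this carbon. Nothing available explains why the response holds across so large a change in the group.

Going by these compounds, what an amine, a methoxy group or a carboxylic acid at this carbon would do remains open, as does the effect of a plain hydrogen there. On these data alone, it is also open whether compound 3 and compound 4, alike in their largest response, are also alike in the concentration needed to reach it.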